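Substituent exchange on the alkyne of a shared core

A few compounds are considered here, and "the series" means these few. Any claim that something is new, unique, unknown or untested is made for them only; others in the source may bear on it.

Compound 1 `CC(C)(C)OC(=O)NCC#Cc1ccc2c(c1)C=C([N+](=O)[O-])C(C(F)(F)F)O2` in an assay on isolated protein for inhibition of D(1B) dopamine receptor (Homo sapiens); a lower number here means a stronger inhibitor, a higher number a weaker inhibitor: 1250 nM
Compound 2 `O=C(O)c1ccc(C#Cc2ccc3c(c2)C=C([N+](=O)[O-])C(C(F)(F)F)O3)cc1` in this assay: 2100 nM

Compound 1 gives the lower of the two numbers, yet the step of a 1.7-fold higher number from compound 1 to compound 2 (0.23 log units; within the scatter) leaves it within the scatter of compound 2. Compound 3 `C[Si](C)(C)C#Cc1ccc2c(c1)C=C([N+](=O)[O-])C(C(F)(F)F)O2` carries the change (a group of 4 heavy atoms (3 carbon, 1 silicon; no ring) in place of a group of 9 heavy atoms (6 carbon, 1 nitrogen, 2 oxygen; no ring), on a triple-bonded carbon). Among the measured compounds shown here, only the step from compound 1 to compound 2 bears on it, a change at the same triple-bonded carbon, and that step stayed within the scatter. For compound 3 the expected step in this assay is therefore a 1.2-fold higher number from compound 1 to compound 3 (0.08 log units; within the scatter), none beyond the scatter. Compound 3 is estimated at 1500 nM, expected between 600 nM and 4000 nM.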

Compound 3, inhibition constant: 4200 nM
For compound 3 the middle estimate is 2.8-fold (0.45 log units) below the measured one; measured number outside the range, above it.
By their numbers in this assay, from the lowest: compounds 1, 2 and 3 (each within the scatter of the next, the first and the last beyond it).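

At this triple-bonded carbon, the exchange can now shift the number beyond the scatter: a 3.4-fold higher number from compound 1 to compound 3 (0.53 log units; beyond the scatter), with the silicon-bearing group replacing ((tert-butoxycarbonyl)amino)methyl. The same entering group stays within the scatter of the 4-carboxyphenyl compound, at a 2.0-fold higher number from compound 2 to compound 3 (0.30 log units; within the scatter), so the three substituents do not separate into clear levels. No measurement on hand accounts for the step. Open, as far as these compounds go, is how a primary amine or a longer alkyl chain at this carbon would stand against compound 1 on the shared core.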